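Acetyl in place of furoyl on the exocyclic enone

A few compounds are considered here, and "the series" means these few. Any claim that something is new, unique, unknown or untested is made for them only; others in the source may bear on it.

Working notes on a small set of penam-derived enones. In a functional assay on NCI-H1299 cells (Homo sapiens) for cytotoxicity, read by MTT assay, with a stated time of 48 h (on this read-out higher numbers stand for weaker inhibition and lower numbers for stronger inhibition), compound 1 `CC1(C)S[C@@H]2/C(=C\C(=O)c3ccco3)C(=O)N2[C@H]1C(=O)OC(c1ccccc1)c1ccccc1` gives 61500 nM, the highest of the three numbers measured. Compound 2 `CC1(C)[C@H](C(=O)OC(c2ccccc2)c2ccccc2)N2C(=O)/C(=C/C(=O)c3ccccc3)[C@H]2S1(=O)=O` gives 50100 nM in this assay, which sits within the scatter of compound 1. Compound 3 `CC1(C)S[C@@H]2/C(=C\C(=O)OC(c3ccccc3)c3ccccc3)C(=O)N2[C@H]1C(=O)OC(c1ccccc1)c1ccccc1` gives 22400 nM, a lower number than compound 1 and beyond the scatter, so compound 3 is the only one of the three that separates from compound 1.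

Compound 4 `CC(=O)/C=C1/C(=O)N2[C@@H]1SC(C)(C)[C@@H]2C(=O)OC(c1ccccc1)c1ccccc1` differs from compound 1 by methyl in place of furan-2-yl on a carbonyl carbon. Among the compounds with values here, no measured pair shows this change, so the expectation rests on the spread of the three known numbers, all of which lie in a narrow, weak band. The step of a 1.3-fold higher number from compound 1 to compound 4 (0.11 log units; within the scatter) is expected to stay within the scatter, leaning if anything toward a higher number. Compound 4 is therefore expected to give 80000 nM in this assay, within a range of 30000 nM to 200000 nM.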

Compound 4, half-maximal inhibitory concentration: 24200 nM
Beside the measured number, compound 4's estimate is 3.3-fold (0.52 log units) above it; measured number below the stated range.
By their numbers in this assay, from the lowest: compounds 3 and 4 (each within the scatter of the next); then compounds 2 and 1 (each within the scatter of the next).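

In this assay, methyl in place of furan-2-yl on a carbonyl carbon brings a 2.5-fold lower number from compound 1 to compound 4 (0.41 log units; beyond the scatter) and so gives the series its first reading of a change in one place. This position therefore responds to the group it carries, and the furan-2-yl ring is not required for the cytotoxicity seen with compound 1, as the single carbon of methyl keeps that activity and gives a modestly lower number. No measurement shown here bears on the origin of this step.

From the compounds shown here alone, whether the lower number holds with a longer chain such as ethyl or propyl, or with an amine on the same carbonyl carbon, remains open. A single step also cannot separate the loss of furan-2-yl from the arrival of methyl.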